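The source may report more compounds than this note shows. Statements on the series, on what has been measured and on what is new or still open speak of the compounds shown alone.

Three compounds share one core and differ only in the ring at the far end of the amide. In a functional assay on MV4-11 cells (Homo sapiens) for antiproliferative activity, with a stated time of 6 days, tested at 6.25 uM (a lower number here means a weaker effect, a higher number a stronger effect of the compound at the concentration tested), compound 1 `CNC(=O)N1CCCc2ccc(NC(=O)c3ccc(-c4cnn(C)c4)cc3)cc21` gives 94.4%, and compound 2 `CNC(=O)N1CCCc2ccc(NC(=O)c3ccc(-c4ccncc4)cc3)cc21` gives 88.7%. Compound 3 `CNC(=O)N1CCCc2ccc(NC(=O)c3ccc(-c4cn[nH]c4)cc3)cc21` gives 98.3% in this assay. Compound 3 sits at the upper end of these three numbers, yet the gaps that separate it from the other two, a number 3.9 percentage points higher from compound 1 to compound 3 (within the scatter) and a number 9.6 percentage points higher from compound 2 to compound 3 (within the scatter), both lie within the scatter, as does a number 5.7 percentage points lower from compound 1 to compound 2 (within the scatter). Compound 4 `CNC(=O)N1CCCc2ccc(NC(=O)c3ccc(-c4cnn(C(C)=O)c4)cc3)cc21` is not yet measured. It arises from compound 3 by one change: acetyl in place of hydrogen on an aromatic nitrogen. The closest comparison is the swap of hydrogen and methyl at the same aromatic nitrogen, a number 3.9 percentage points higher from compound 1 to compound 3 (within the scatter), which stayed within the scatter, and the two ring exchanges were likewise within the scatter. A step of no more than the scatter is therefore expected in this assay for compound 4, a number 5.3 percentage points lower from compound 3 to compound 4 (within the scatter), in no particular direction. Compound 4 is estimated at 93%, between 80% and 99%.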

Compound 4, a percentage reported as inhibition, at one concentration (the size of the read-out at that concentration, not a potency): 83.8%
Beside the measured number, compound 4's estimate is 9.2 percentage points above it, within the range that was stated.
By their numbers in this assay, from the lowest: compounds 4, 2, 1 and 3 (each within the scatter of the next, the first and the last beyond it).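

Within the data shown here, on the aromatic nitrogen of the pyrazole ring, hydrogen and methyl could not be told apart in this assay, but acetyl is the first group at this position to give a step beyond the scatter, with a number 14.5 percentage points lower from compound 3 to compound 4 (beyond the scatter) and with a number 10.6 percentage points lower from compound 1 to compound 4 (beyond the scatter). The change of whole ring gives a different reading, since a number 4.9 percentage points lower from compound 2 to compound 4 (within the scatter), so compound 4 cannot be separated from the pyridin-4-yl compound. Nothing available here bears on what lies behind the lower number for the acetyl compound.

On these data alone, it remains open whether the step follows from the carbonyl attached to this nitrogen or from the size of the group, which an ethyl or a longer carbon chain on the same nitrogen could help to separate. A propanoyl or a methylcarbamoyl group there would show whether other carbonyl groups give a similar step.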